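A few compounds are considered here, and "the series" means these few. Any claim that something is new, unique, unknown or untested is made for them only; others in the source may bear on it.

Working notes on the aminomethyl-thiophene series built on the shared bicyclic core.

Three compounds have numbers in an ADME assay on MDCK cells (Canis lupus familiaris) for cytotoxicity, read by microscopy, with a stated time of 48 h; on this read-out higher numbers stand for lower toxicity in this test and lower numbers for higher toxicity in this test. Compound 1, `C[C@H]1[C@H](NCc2cc(-c3ccccc3)cs2)C[C@H]2C[C@@H]1C2(C)C`, gives 5000 nM. Compound 2, `C[C@H]1[C@H](NCc2ccco2)C[C@H]2C[C@@H]1C2(C)C`, the furan analogue, gives 50000 nM. Compound 3, `C[C@H]1[C@H](NCc2cc(C3CCCCC3)cs2)C[C@H]2C[C@@H]1C2(C)C`, gives 780 nM, the lowest of the three: compound 1 sits closest, and compound 2 furthest. Among the compounds with values here, the one single-site step in the set runs a 6.4-fold lower number from compound 1 to compound 3 (0.81 log units; beyond the scatter), so the cyclohexyl carries the lowest number seen here.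

Compound 4, `C[C@H]1[C@H](NCc2cc(Br)cs2)C[C@H]2C[C@@H]1C2(C)C`, has not been measured. Relative to compound 3 the change is bromo in place of cyclohexyl on an aromatic carbon: a group of six heavy atoms in a ring gives way to a single heavy atom on the same aromatic carbon. Within the data shown here, no measured step tests bromo directly. The step from compound 1 to compound 3 is the only one that bears on it, and it shows that exchanging the group at this carbon moved the number beyond the scatter. With the large ring gone altogether, the expectation is that the number moves back toward the values of compound 1 and compound 2, upward, beyond the scatter. The estimate for compound 4 is therefore 5000 nM, between 1500 nM and 25000 nM, an expected step of a 6.4-fold higher number from compound 3 to compound 4 (0.81 log units; beyond the scatter).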

Compound 4, minimum cytotoxic concentration: 6250 nM
Beside the measured number, compound 4's estimate is 1.3-fold (0.10 log units) below it; the range from low to high includes it.
By their numbers in this assay, from the lowest: compound 3; then compounds 1 and 4 (each within the scatter of the next); then compound 2.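

In this assay the cyclohexyl now stands apart at this aromatic carbon, two ring bonds from the ring sulfur: the exchange for bromo gives an 8.0-fold higher number from compound 3 to compound 4 (0.90 log units; beyond the scatter) while the exchange of phenyl for bromo gives a 1.3-fold higher number from compound 1 to compound 4 (0.10 log units; within the scatter) and so separates neither group from the other. A ring at this carbon therefore does not set the number by itself, since phenyl in compound 1 and bromo in compound 4 cannot be told apart and only cyclohexyl in compound 3 goes lower. The change at the saturated chain carbon bound to an amine nitrogen gives an 8.0-fold lower number from compound 2 to compound 4 (0.90 log units; beyond the scatter) and shows that the 4-bromothiophen-2-yl stays apart from the furan-2-yl even without a large ring, though nothing available here accounts for any of these steps.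

As far as these compounds go, whether the low number belongs to cyclohexyl alone or extends to other saturated carbon groups stays open, and a cyclopropyl, a tert-butyl or a longer chain on the same aromatic carbon would separate those readings. Also open, from the compounds shown here alone, is where an amine, a carboxylic acid or a plain hydrogen at this carbon would fall against compound 4 and compound 2.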